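This account rests on a few compounds, and the source may have more. Where it says the series, first, only, none or still open, it means among the compounds named here.

Working notes on the sulfonamide series in a functional assay on DLD-1 cells (Homo sapiens) for antiproliferative activity, read by CellTiter-Glo, with a stated time of 72 h; a higher number here means a weaker inhibitor, a lower number a stronger inhibitor.

Compound 1, `CC1CCN(C2CCN(S(=O)(=O)c3ccc(OCc4ccccc4)cc3)CC2)CC1`, gives 385 nM in this assay. Against the other two measured compounds it stands second highest of the three numbers. Compound 3, `CC1CCN(C2CCN(S(=O)(=O)c3cccnc3)CC2)CC1`, gives 2400 nM, the higher number of the pair and a gap beyond the usual scatter. Compound 2, `Cc1cc(C)c(S(=O)(=O)N2CCC(N3CCCCCC3)CC2)c(C)c1`, gives 5.3 nM, a far lower number and the furthest from compound 1. No single-point change links any of these three, so the numbers are read as they stand, without a step between them.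

The next compound, compound 4, `CC1CCN(C2CCN(S(=O)(=O)c3ccc(-c4ccc(Cl)cc4)cc3)CC2)CC1`, is not yet measured. It differs from compound 1 in one place: 4-chlorophenyl in place of benzyloxy on an aromatic carbon. The group that leaves, benzyloxy, and the group that enters, 4-chlorophenyl, each carry one six-membered aromatic ring of carbon only and sit on the same aromatic carbon, para to a large group; the change removes the oxygen and its one hydrogen-bond acceptor and brings in a chlorine.

Nothing measured here tells what this exchange does, and a step in either direction, or none beyond the scatter, is possible. The working expectation for compound 4 is a number near that of compound 1, estimated at 300 nM with a range of 80 nM to 1200 nM, meaning an expected step of a 1.3-fold lower number from compound 1 to compound 4 (0.11 log units; within the scatter).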

Compound 4, half-maximal inhibitory concentration: 105 nM
The estimate for compound 4 lay 2.9-fold (0.46 log units) above the measured number; the measured number falls inside the stated range.
By their numbers in this assay, from the lowest: compound 2; then compound 4; then compound 1; then compound 3.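

On an aromatic carbon para to a large group, 4-chlorophenyl in place of benzyloxy gives a 3.7-fold lower number from compound 1 to compound 4 (0.56 log units; beyond the scatter) in this assay, so this position is not indifferent to which aromatic substituent it carries. The oxygen of benzyloxy and its hydrogen-bond acceptor are also not needed to reach the lower number of this pair, although the same exchange brings in a chlorine and this single step cannot separate the loss of one atom from the gain of the other. No measurement at hand gives a reason for the step.

The compounds shown leave open how much of the step belongs to the chlorine and how much to the loss of the oxygen, a question that a plain phenyl group at this aromatic carbon, or a 4-chlorobenzyloxy group, would help to divide. They also leave open whether this position accepts anything other than a large carbon-ring substituent, such as an amine or a carboxylic acid on the outer ring, and whether the exchange holds on any other core.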